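Bromo for Chloro Repeated on a Second Core

The source may report more compounds than this note shows. Statements on the series, on what has been measured and on what is new or still open speak of the compounds shown alone.

In a functional assay on MCF7 cells (Homo sapiens) for antiproliferative activity, read by MTT assay, with a stated time of 48 h (on this read-out lower numbers stand for stronger inhibition and higher numbers for weaker inhibition), three compounds have been measured so far:

compound 1, `N=C(N)N/N=C(/C=C/c1ccc(Cl)cc1)c1ccccc1`: 700 nM
compound 2, `N=C(N)N/N=C(/C=C/c1ccc(Br)cc1)c1ccccc1`: 250 nM
compound 3, `N=C(N)N/N=C(/C=C/c1ccccc1)c1ccc(Cl)cc1`: 350 nM

Compound 1 and compound 2 differ by bromo in place of chloro on an aromatic carbon, and in this assay this gives a 2.8-fold lower number from compound 1 to compound 2 (0.45 log units; beyond the scatter). Compound 3 is built from the same atoms as compound 1, joined differently; the difference between the two cores is not broken down here. Compound 4, `N=C(N)N/N=C(/C=C/c1ccccc1)c1ccc(Br)cc1`, has not yet been measured in this assay. It differs from compound 3 by bromo in place of chloro on an aromatic carbon, the same change, at a place described in the same words, as from compound 1 to compound 2. Resting on that single precedent, and allowing that a change on one core need not repeat in full on another, compound 4 is expected to show a 1.9-fold lower number from compound 3 to compound 4 (0.29 log units; within the scatter). The estimate for compound 4 is 180 nM, with a range from 80 nM to 400 nM.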

Compound 4, half-maximal inhibitory concentration: 90 nM
Beside the measured number, compound 4's estimate is 2.0-fold (0.30 log units) above it; measured number inside the range.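

Bromo in place of chloro lowers the number on the second core as well, giving a 3.9-fold lower number from compound 3 to compound 4 (0.59 log units; beyond the scatter) in this assay. Set beside the earlier step, the two agree: the same change on two cores in this assay, a 2.8-fold lower number (0.45 log units; beyond the scatter) from compound 1 to compound 2 and a 3.9-fold lower number (0.59 log units; beyond the scatter) from compound 3 to compound 4, 1.4-fold (0.14 log units) apart, within the scatter of two such steps. Among these compounds, this shows that the change carried over between these two cores with its size intact within the scatter, but it rests on only two pairs in one cell line, so it does not show that the change would carry to any other core, nor why the number falls.

The compounds shown leave open whether iodo, fluoro or methoxy in place of bromo would continue the trend. They also leave open what bromo on both aromatic rings would give.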